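This account rests on a few compounds, and the source may have more. Where it says the series, first, only, none or still open, it means among the compounds named here.

Working notes on the series. In a toxicity assay on MDCK cells (Canis lupus familiaris) for cytotoxicity, read by CCK-8 assay, with a stated time of 48 h (a lower number here means that less compound is tolerated, a higher number that more compound is tolerated), compound 1 (`CCCCOc1ccc(C(=O)NNc2c(Br)cccc2Br)cc1`) gives > 100000 nM as a limit of the assay, not a number. Compound 2 (`O=C(NNc1c(Br)cccc1Br)c1ccc(F)cc1`) gives > 100000 nM as a limit too. Compound 3 (`O=C(NNc1c(Br)cccc1Br)c1ccc(Br)cc1`) gives > 100000 nM as a limit as well, so it has no numeric position in the series. The evidence so far is simply the limit of > 100000 nM in this assay, at which 3 of the 3 values shown sit, and nothing more.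

Compound 4 (`O=C(NNc1c(Br)cccc1Br)c1ccc(-c2ccccc2)cc1`) differs from compound 3 by one change: phenyl in place of bromo on an aromatic carbon. The aromatic carbon concerned is para to a large group.

The measured steps that bear on this change are a step that the two limits leave unreadable from compound 1 to compound 2, a step that the two limits leave unreadable from compound 1 to compound 3 and a step that the two limits leave unreadable from compound 2 to compound 3. None of them has a readable size, so no size can be carried over to the new change. The expectation therefore rests on compound 3 at > 100000 nM as its starting limit.

No step beyond the scatter is expected in this assay, in either direction, and the estimated change is a number no higher from compound 3 to compound 4 (the limit leaves the size open) for now. Compound 4 is estimated at 100000 nM with an expected range from 40000 nM to 200000 nM and a good chance of coming out only as a limit.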

Compound 4, half-maximal cytotoxic concentration: 84100 nM
Estimate against measurement, compound 4: 1.2-fold (0.08 log units) above, and the stated range covers the measured number.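

In this assay, going by these compounds alone, the aromatic carbon para to a large group carries the first step that can be read at all, with an at least 1.1-fold lower number from compound 3 to compound 4 (0.07 log units; that floor lies within the scatter) as a floor and not as a size. The same floor holds with an at least 1.1-fold lower number from compound 2 to compound 4 (0.07 log units; that floor lies within the scatter) and with an at least 1.1-fold lower number from compound 1 to compound 4 (0.07 log units; that floor lies within the scatter) on this carbon, which makes phenyl the one group shown that gives a number in place of a limit, while the steps among compound 1, compound 2 and compound 3 cannot be read. Within the data shown here, the series still stands mostly on that limit, and the single number in it gives a position for phenyl but no trend across groups: the limit of > 100000 nM in this assay, at which 3 of the 4 values shown sit.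

As far as these compounds go, how far the true steps to compound 4 reach stays open, as the values on the other side of each step are limits and not numbers. Also open, from the compounds shown here alone, is whether an amine, a carboxylic acid or a longer chain such as hexyloxy on this same aromatic carbon would give a number in this assay, and whether that number would lie close to the one for phenyl or well away from it.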